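From 4-isopropylphenyl to 2,4,6-trimethylphenyl on a shared core

The compounds below may be only part of what the source reports. "The series", "measured", "known", "first", "only" and "open" are said of these compounds alone.

Compound 1 `CN1CCN(c2ccc(Nc3ncc(Cl)c(NCc4ccccc4)n3)nc2)CC1` gives 24800 nM
Compound 2 `CC(C)c1ccc(Nc2nc(Nc3ccc(N4CCN(C)CC4)cn3)ncc2Cl)cc1` gives 7020 nM

In a functional assay on MDA-MB-231 cells (Homo sapiens) for inhibition, read by CCK-8 assay, with a stated time of 48 h (on this read-out lower numbers stand for stronger inhibition of growth and higher numbers for weaker inhibition of growth), compound 2 gives 7020 nM as the lower of the two numbers. Compound 3 `Cc1cc(C)c(Nc2nc(Nc3ccc(N4CCN(C)CC4)cn3)ncc2Cl)c(C)c1` differs from it by 2,4,6-trimethylphenyl in place of 4-isopropylphenyl on a nitrogen on an aromatic ring with 2,4,6-trimethylphenyl in place of 4-isopropylphenyl on a nitrogen on an aromatic ring. Going by the values given here, one measured step bears on this place: a 3.5-fold lower number from compound 1 to compound 2 (0.55 log units; beyond the scatter) is modest, and it replaced benzyl, so it does not test the new group. From the compounds shown here alone, no step beyond the scatter is therefore expected, and the direction stays open. The estimate means a 1.1-fold higher number from compound 2 to compound 3 (0.06 log units; within the scatter) as the expected step. Compound 3 is expected at 8000 nM with an estimated range from 2800 nM to 23000 nM.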

Compound 3, concentration for 50% growth inhibition: 21000 nM
Estimate against measurement, compound 3: 2.6-fold (0.42 log units) below, and the stated range covers the measured number.
By their numbers in this assay, from the lowest: compound 2; then compounds 3 and 1 (each within the scatter of the next).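

In this assay, the exchange of one nine-carbon aryl group for another is not neutral at this nitrogen: a 3.0-fold higher number from compound 2 to compound 3 (0.48 log units; beyond the scatter), although both groups have the same atoms and the same ring. Against the benzyl group the picture differs, with a 1.2-fold lower number from compound 1 to compound 3 (0.07 log units; within the scatter), so the advantage seen with 4-isopropylphenyl does not extend to 2,4,6-trimethylphenyl. Nothing available explains this difference. The compounds shown leave open how a plain phenyl, or a phenyl carrying a single methyl or methoxy group, would read at this nitrogen.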